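The compounds below may be only part of what the source reports. "The series", "measured", "known", "first", "only" and "open" are said of these compounds alone.

Series notes. Compound 1 `COc1c(Br)cccc1C(=O)Nc1ccc(Sc2nc3ccccc3s2)c(Cl)c1` gives 11000 nM in a functional assay on HT-29 cells (Homo sapiens) for cytotoxicity, read by resazurin assay, with a stated time of 48 h; on this read-out lower numbers stand for an effect already at smaller amounts and higher numbers for an effect only at larger amounts of compound. Compound 2 `O=C(Nc1ccc(Sc2nc3ccccc3s2)c(Cl)c1)c1cccc(Br)c1O` gives 20000 nM in this assay, and the step of a 1.8-fold higher number from compound 1 to compound 2 (0.26 log units; within the scatter) is the only one measured between two neighbouring compounds. Compound 3 `COc1ccc(S(=O)(=O)Nc2ccc3oc(-c4ccc(NC(=O)c5ccc(Cl)s5)cc4)nc3c2)cc1` is built on a different core and gives 1900 nM in this assay, the lowest of the three numbers; its gaps to compound 1 and to compound 2 are both beyond the scatter. Compound 4 `COc1ccc(S(=O)(=O)Nc2ccc3oc(-c4ccc(NC(=O)C5CCN(C(C)=O)CC5)cc4)nc3c2)cc1` is the next compound to be measured. It differs from compound 3 in one place: 1-acetylpiperidin-4-yl in place of 5-chlorothiophen-2-yl on a carbonyl carbon. For the measured compounds named here, no measured step bears on this change; the single measured step concerns a different core and a different kind of change, so it gives neither size nor direction. The expected step of a 2.1-fold higher number from compound 3 to compound 4 (0.32 log units; beyond the scatter) is therefore a modest move toward higher numbers, not clearly beyond the scatter, with wide uncertainty. Compound 4 is estimated at 4000 nM in this assay, between 1200 nM and 15000 nM.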

Compound 4, half-maximal effective concentration: 16000 nM
For compound 4 the middle estimate is 4.0-fold (0.60 log units) below the measured one, and the stated range ends below it.
By their numbers in this assay, from the lowest: compound 3; then compounds 1, 4 and 2 (each within the scatter of the next).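

At the carbonyl carbon on the amide-type nitrogen, replacing 5-chlorothiophen-2-yl with 1-acetylpiperidin-4-yl in this assay gives an 8.4-fold higher number from compound 3 to compound 4 (0.93 log units; beyond the scatter). This is the only step shown on the core of compound 3, and unlike a 1.8-fold higher number from compound 1 to compound 2 (0.26 log units; within the scatter), it lies beyond the scatter, so the group at this place does move the number on this core. No measurement on hand explains the step.

For the compounds shown here, the single step exchanges a five-membered aromatic ring for a six-membered non-aromatic ring and also brings in the acetyl, so the contribution of each part remains unresolved. Also open, as far as these compounds go, is how the number responds at this place to piperidin-4-yl without the acetyl, thiophen-2-yl without the chlorine, or a phenyl ring.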